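A few compounds are considered here, and "the series" means these few. Any claim that something is new, unique, unknown or untested is made for them only; others in the source may bear on it.

Measured in a functional assay on MCF7 cells (Homo sapiens) for inhibition, read by MTT assay, with a stated time of 48 h; on this read-out lower numbers stand for stronger inhibition and higher numbers for weaker inhibition:
- Compound 1 `O=C(CC(c1ccccc1)C(C(=O)Nc1ccccn1)C(=O)Nc1ccccn1)c1ccccc1`: "not active" (no number reported)
- Compound 2 `O=C(CC(c1ccc(Cl)cc1)C(C(=O)Nc1ccccn1)C(=O)Nc1ccccn1)c1ccccc1`: 19100 nM
- Compound 3 `O=C(CC(c1ccc(Cl)cc1)C(C(=O)Nc1ccccn1)C(=O)Nc1ccccn1)c1ccc(F)cc1`: 21200 nM

Only compound 2 and compound 3 give numbers in this assay, and those two numbers lie within the scatter of each other. Compound 4 `O=C(CC(c1cccs1)C(C(=O)Nc1ccccn1)C(=O)Nc1ccccn1)c1ccccc1` has not yet been measured. Its difference from compound 2 is thiophen-2-yl in place of 4-chlorophenyl on a saturated chain carbon bound to two saturated chain carbons: thiophen-2-yl replaces 4-chlorophenyl, while the rest of the structure stays the same.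

For the measured compounds named here, only one measured step gives a size: a 1.1-fold higher number from compound 2 to compound 3 (0.05 log units; within the scatter). That step is a fluoro in place of hydrogen on an aromatic carbon, which is a different change, so it offers only weak guidance here. A second hint is that compound 1 gives "not active" (no number reported), whereas compound 2 gives 19100 nM. A result without a number therefore remains possible for compound 4. A modest move toward a higher number is expected, not clearly beyond the scatter. The expected step is a 1.5-fold higher number from compound 2 to compound 4 (0.17 log units; within the scatter). The estimate for compound 4 is 28000 nM, with an expected range from 12000 nM to 70000 nM.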

Compound 4, half-maximal inhibitory concentration: "not active" (no number reported)
Compound 4 has no reported number here, and the estimate cannot be compared.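

Compound 4 has no number to set against compound 2, so no step between them can be read, and no measurement here explains the result. The compounds shown leave open how large the effect of exchanging 4-chlorophenyl for thiophen-2-yl is.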